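One Methoxy Fewer: Expecting a Stronger Effect

The compounds below may be only part of what the source reports. "The series", "measured", "known", "first", "only" and "open" are said of these compounds alone.

Of the compounds shown here, two sharing one core have been tested in a functional assay on SR cells (Homo sapiens) for cytotoxicity, read by sulforhodamine B assay, with a stated time of 48 h, tested at 100 uM; on this read-out higher numbers stand for a weaker effect at the one concentration tested and lower numbers for a stronger effect. Compound 1 `COc1ccc(-c2cc(/C=C/C(=O)c3ccc(N)cc3)[nH]n2)cc1` gives -61% in this assay, whereas compound 2 `COc1cc(-c2cc(/C=C/C(=O)c3ccc(N)cc3)[nH]n2)cc(OC)c1OC` gives -13%, the highest of the two numbers and a gap beyond the usual scatter. Compound 3 `COc1ccc(-c2cc(/C=C/C(=O)c3ccc(N)cc3)[nH]n2)cc1OC` has not yet been measured; it differs from compound 2 by hydrogen in place of methoxy on an aromatic carbon. A downward step beyond the scatter is expected, because compound 1, carrying fewer methoxy groups, gives -61%. Compound 3 is therefore estimated at -38%, within a range from -65% to -10%. That estimate means an expected step of a number 25 percentage points lower from compound 2 to compound 3 (beyond the scatter).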

Compound 3, a percentage reported as activity, at one concentration (the size of the read-out at that concentration, not a potency): -5%
Compound 3: the middle estimate sits 33 percentage points below what was measured, outside the stated range (above it).
By their numbers in this assay, from the lowest: compound 1; then compounds 2 and 3 (each within the scatter of the next).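

In this assay removing this methoxy group leaves the effect essentially unchanged, with a number 8 percentage points higher from compound 2 to compound 3 (within the scatter) as the step. Adding a methoxy group to the ring of compound 1 matters far more, giving a number 56 percentage points higher from compound 1 to compound 3 (beyond the scatter) for that single change, so the same kind of swap has very different consequences in these two steps. Nothing measured here explains that contrast.

On these data alone, whether a hydroxyl group or a fluorine atom on this aromatic carbon would behave like hydrogen or like methoxy remains open.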